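This account rests on a few compounds, and the source may have more. Where it says the series, first, only, none or still open, it means among the compounds named here.

Measured so far:
compound 1 `Oc1cccc(-c2cc(-c3cccc(O)c3)nc(-c3ccccc3O)c2)c1` — 50000 nM
compound 2 `Oc1ccc(-c2cc(-c3ccccc3O)cc(-c3ccccc3O)n2)cc1` — 960 nM

Within the data shown here, in a functional assay on T47D cells (Homo sapiens) for cytotoxicity, read by CCK-8 assay, with a stated time of 4 days (a lower number here means a stronger inhibitor, a higher number a weaker inhibitor), compound 2 gives 960 nM, the lowest of the two numbers recorded; the only neighbour, compound 1, gives 50000 nM, a gap well beyond the scatter. Compound 3 `Oc1ccc(-c2cc(-c3cccc(O)c3)cc(-c3ccccc3O)n2)cc1` is not yet measured in this assay. It differs from compound 2 by 3-hydroxyphenyl in place of 2-hydroxyphenyl on an aromatic carbon. With the same atoms joined differently, compound 3 carries two rings in the arrangement found in compound 1, so the step from compound 2 to compound 3 is expected to run toward weaker inhibition and to exceed the scatter, because compound 1 with two 3-hydroxyphenyl groups gives 50000 nM. Among the measured compounds shown here, only one such ring is exchanged here, so the full distance to compound 1 is not expected. Compound 3 is estimated to fall at 6000 nM, between 1500 nM and 25000 nM, which means a step of a 6.3-fold higher number from compound 2 to compound 3 (0.80 log units; beyond the scatter).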

Compound 3, half-maximal inhibitory concentration: 50000 nM
Compound 3: the middle estimate sits 8.3-fold (0.92 log units) below what was measured, and the stated range ends below it.
By their numbers in this assay, from the lowest: compound 2; then compounds 1 and 3 (each within the scatter of the next).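

In this assay, 3-hydroxyphenyl in place of 2-hydroxyphenyl on the aromatic carbon opposite the ring nitrogen gives a 52-fold higher number from compound 2 to compound 3 (1.72 log units; beyond the scatter) and so marks this position as sensitive to where the hydroxyl group sits on its ring, a point the earlier pair could not isolate. With 3-hydroxyphenyl held at that position, 4-hydroxyphenyl in place of 3-hydroxyphenyl on an aromatic carbon gives no change at the digits printed from compound 1 to compound 3 (within the scatter) in the same assay, so this second exchange leaves no reading beyond the scatter. Nothing at hand accounts for the large step.

Still open, going by these compounds, is whether the position opposite the ring nitrogen tolerates anything other than a hydroxyphenyl group. A methoxyphenyl, an aminophenyl or an unsubstituted phenyl group there would show whether the 2-hydroxyphenyl arrangement of compound 2 can be matched.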